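Fluoro to trifluoromethyl swaps in a small series

The source may report more compounds than this note shows. Statements on the series, on what has been measured and on what is new or still open speak of the compounds shown alone.

Compound 1 `C[C@@H](NC(=O)Nc1ccc(C(F)(F)F)cc1)c1ccccc1` gives 93% in an ADME assay on the whole organism with Oryza sativa as the target, tested at 0.1 uM; on this read-out higher numbers stand for a weaker effect at the one concentration tested and lower numbers for a stronger effect. Compound 2 `C[C@@H](NC(=O)Nc1ccc(F)cc1)c1ccccc1` gives 98% in this assay, and compound 3 `C[C@@H](NC(=O)Nc1cccc(F)c1F)c1ccccc1` gives 100% in this assay. All three numbers lie within the scatter of one another. Among the compounds with values here, the only single-point step measured so far, a number 5 percentage points lower from compound 2 to compound 1 (within the scatter), goes with trifluoromethyl in place of fluoro on an aromatic carbon. The same kind of change separates compound 3 from compound 4 `C[C@@H](NC(=O)Nc1cccc(C(F)(F)F)c1F)c1ccccc1`, which is not yet measured: trifluoromethyl in place of fluoro on an aromatic carbon. The surroundings differ, though: in compound 4 the place is ortho to a fluoro group and meta to a large group, whereas in compound 1 it is para to a large group. How the core of compound 3 differs from that of compound 2 is not broken down here. A step of a number 3 percentage points lower from compound 3 to compound 4 (within the scatter) in this assay is expected, because a number 5 percentage points lower from compound 2 to compound 1 (within the scatter) stayed within the scatter. Compound 4 is therefore expected to give 97% in this assay, with a likely range from 88% to 100%.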

Compound 4, a percentage reported as activity, at one concentration (the size of the read-out at that concentration, not a potency): 99%
Beside the measured number, compound 4's estimate is 2 percentage points below it, and the stated range covers the measured number.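

In this assay, trifluoromethyl in place of fluoro goes with a number 1 percentage points lower from compound 3 to compound 4 (within the scatter). Set beside the earlier step, the change reads alike on the two cores: the same change on two cores in this assay, a number 5 percentage points lower (within the scatter) from compound 2 to compound 1 and a number 1 percentage points lower (within the scatter) from compound 3 to compound 4, 4 percentage points apart, within the scatter of two such steps. Within the data shown here, this shows only that the change stays within the scatter on both cores at the one concentration tested; it does not show a real effect that carries from core to core, nor does it separate the surroundings of compound 4, where the place is ortho to a fluoro group and meta to a large group.

Open, as far as these compounds go, is whether any group at this place moves the read-out beyond the scatter, for example an amine, a carboxylic acid or a longer chain. Also open, from the compounds shown here alone, is how the change behaves at other concentrations.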